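Bromophenyl Ether in Place of a Methoxyethoxy Chain

A few compounds are considered here, and "the series" means these few. Any claim that something is new, unique, unknown or untested is made for them only; others in the source may bear on it.

Measured compounds:
compound 1, `Cc1cccc(COc2ccc3c(c2)[C@@H](O)CN(C)C3)c1`, gives > 50000 nM in an ADME assay on Vero cells (Chlorocebus sabaeus) for cytotoxicity, read by sulforhodamine B assay, with a stated time of 72 h; a higher number here means a weaker inhibitor, a lower number a stronger inhibitor
compound 2, `COCCOCOc1ccc2c(c1)[C@@H](O)CN(C)C2`, gives > 50000 nM in this assay

Compound 2 stands at a limit of this assay, not at a number. Among the compounds with values here, the one other value shown is also a limit, so nothing places compound 2 relative to compound 1 within the scatter or beyond it. Both values sit at the limit of > 50000 nM in this assay, at which 2 of the 2 values shown sit.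

Compound 3, `CN1Cc2ccc(OCc3ccc(Br)cc3)cc2[C@@H](O)C1`, differs from compound 2 by 4-bromophenyl in place of 2-methoxyethoxy on a saturated chain carbon bound to an oxygen on an aromatic ring. Within the data shown here, the only measured step, a step that the two limits leave unreadable from compound 1 to compound 2, is not readable in size or direction, so it gives no scale for the change. What the data do show is that compound 1, which carries 3-methylphenyl on a saturated chain carbon bound to an oxygen on an aromatic ring, sits at the same limit as compound 2. Compound 3 returns an aromatic ring to that place, and on that evidence no step beyond the scatter is expected for it: the estimated step is a step that the limit leaves unreadable from compound 2 to compound 3. Compound 3 is therefore expected to give about 60000 nM in this assay, within a range from 25000 nM to 200000 nM, most likely reported again as a limit.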

Compound 3, half-maximal inhibitory concentration: 37000 nM
Beside the measured number, compound 3's estimate is 1.6-fold (0.21 log units) above it, and the stated range covers the measured number.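

In this assay, within the data shown here, compound 3 gives 37000 nM, the first value at this place that is a number, with 4-bromophenyl on the saturated chain carbon bound to an oxygen on an aromatic ring. Compound 1 and compound 2 remain at a limit, not a number: the limit of > 50000 nM in this assay, at which 2 of the 3 values shown sit. Replacing the 2-methoxyethoxy group gives an at least 1.3-fold lower number from compound 2 to compound 3 (0.13 log units; that floor lies within the scatter), and replacing the 3-methylphenyl group gives an at least 1.3-fold lower number from compound 1 to compound 3 (0.13 log units; that floor lies within the scatter), so this place can hold a group that brings the read-out inside the measurable range of the assay, yet neither step is shown to go beyond the scatter.

Going by these compounds, how large either step really is remains open, since the true values of compound 1 and compound 2 lie somewhere past their shared limit, and compound 1 and compound 3 differ both in the substituent on the ring and in where it sits. The compounds shown also leave open what a plain phenyl, a 4-chlorophenyl or a chain ending in an amine would give at this place, and so whether the bromine or the aromatic ring goes with the measured number.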